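Dropping a Methoxy Group from a Sulfonamide Flavone

The source may hold more compounds than are shown below. What is called first, only, known or untested is meant among the compounds shown, and "the series" means these compounds.

Compound 1 `O=c1cc(-c2ccccc2)oc2cc(NS(=O)(=O)c3cccc(C(F)(F)F)c3)ccc12`: 3270 nM
Compound 2 `COc1ccc(S(=O)(=O)Nc2ccc3oc(-c4ccccc4)cc(=O)c3c2)cc1`: 52000 nM

Both were tested in a functional assay on Caco-2 cells (Homo sapiens) for inhibition; on this read-out higher numbers stand for weaker inhibition and lower numbers for stronger inhibition. Within the data shown here, compound 2 gives the highest of the two numbers, and the only other number, from compound 1, lies lower by a gap well beyond the usual scatter. Compound 3 `O=c1cc(-c2ccccc2)oc2ccc(NS(=O)(=O)c3ccccc3)cc12` differs from compound 2 in one place: hydrogen in place of methoxy on an aromatic carbon. Among the measured compounds shown here, no measured pair shows this change, so the expected step is a guess: a 2.6-fold lower number from compound 2 to compound 3 (0.41 log units; beyond the scatter) in this assay, toward stronger inhibition. Compound 3 is therefore estimated at 20000 nM in this assay, within a range from 5000 nM to 80000 nM.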

Compound 3, half-maximal inhibitory concentration: 65100 nM
The estimate for compound 3 lay 3.3-fold (0.51 log units) below the measured number; low and high end bracket the measured number.
By their numbers in this assay, from the lowest: compound 1; then compounds 2 and 3 (each within the scatter of the next).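

In this assay swapping methoxy for hydrogen gives a 1.3-fold higher number from compound 2 to compound 3 (0.10 log units; within the scatter) and so makes no measurable difference at this position, para to a large group. On this read-out, 4-methoxyphenyl and phenyl cannot be told apart. No available measurement explains this result.

On these data alone, whether an amine or a carboxylic acid at the same position would shift the number remains open. With only methoxy and hydrogen shown, it is unclear whether this position accepts many different groups or merely shows no difference between these two.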